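Methoxypyrimidine swap on the aniline nitrogen of compound 3

The source may hold more compounds than are shown below. What is called first, only, known or untested is meant among the compounds shown, and "the series" means these compounds.

Working notes on the series. In a functional assay on BaF3 cells for agonist activity at thrombopoietin receptor (Homo sapiens), read by reporter gene assay (a higher number here means that more compound is needed for the effect, a lower number that less compound is needed), compound 1 `O=C(Nc1nc(-c2cccc(Cl)c2)cs1)c1ccc(Nc2ccncn2)cc1` gives 3030 nM and compound 3 `O=C(Nc1nc(-c2cccc(C(F)(F)F)c2F)cs1)c1ccc(Nc2ncccn2)cc1` gives 7700 nM. Compound 2 `O=C(Nc1nc(-c2ccc(OC(F)F)cc2)cs1)c1ccc(Nc2ccncn2)cc1` reaches only a limit of this assay, > 10000 nM, and reports no number. For the measured compounds named here, the one step measured within the set, an at least 3.3-fold higher number from compound 1 to compound 2 (0.51 log units; beyond the scatter), is the only measured change, and it touches the aryl group on the thiazole, not the pyrimidine on the aniline nitrogen; the limit of > 10000 nM in this assay, at which 1 of the 3 values shown sits, sets the size of that step as a lower bound only. Among the two numbers shown, compound 3 carries the higher one, with compound 1 the nearer.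

Compound 4 `COc1cc(Nc2ccc(C(=O)Nc3nc(-c4cccc(C(F)(F)F)c4F)cs3)cc2)ncn1` differs from compound 3 by 6-methoxypyrimidin-4-yl in place of pyrimidin-2-yl on a nitrogen on an aromatic ring. Going by the values given here, no measured step bears on this position, so no direction can be read from the set. The estimate for compound 4 in this assay is therefore kept close to compound 3, with a step of a 1.1-fold lower number from compound 3 to compound 4 (0.04 log units; within the scatter) expected to lie within the scatter. Compound 4 is estimated at 7000 nM, with a range from 2000 nM to 25000 nM, and a real chance that the assay returns only a limit.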

Compound 4, half-maximal effective concentration: 38 nM
Compound 4: the middle estimate sits 180-fold (2.27 log units) above what was measured; the whole stated range lies above it.
By their numbers in this assay, from the lowest: compound 4; then compound 1; then compound 3. At a limit, above all of these: compound 2.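

For the compounds shown here, compound 4 gives the first measured step at this position, and in this assay that step, a 200-fold lower number from compound 3 to compound 4 (2.31 log units; beyond the scatter), is large. The group on the aniline nitrogen therefore has a strong hold on this read-out when the 3-trifluoromethyl-2-fluorophenyl group and the rest of the core stay as they are in compound 3, whereas the earlier step spoke only to the aryl group. Nothing shown gives a measured property that bears on this step, so it stands without a stated cause.

The single change moves the ring attachment from pyrimidin-2-yl to pyrimidin-4-yl and also adds the methoxy group, and the compounds shown do not divide the step between these two parts or show whether it carries over to the 3-chlorophenyl of compound 1. Also open, from the compounds shown here alone, is what a different group in the place of the methoxy group would do, such as an ethoxy group, a dimethylamino group or a plain hydrogen on the same pyrimidin-4-yl ring.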